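A methylsulfonyl swap on a compound at the limit

This account rests on a few compounds, and the source may have more. Where it says the series, first, only, none or still open, it means among the compounds named here.

Compound 1 `COc1ccc([C@H]2CC(=O)N(c3cccc(N(C)C)c3)C2)cc1OC1CCCC1`: > 10000 nM
Compound 2 `COc1ccc([C@H]2CC(=O)N(c3ccc(C#N)cc3)C2)cc1OC1CCCC1`: > 10000 nM
Compound 3 `COc1ccc([C@H]2CC(=O)N(c3ccc(C(F)(F)F)cc3)C2)cc1OC1CCCC1`: > 10000 nM

These results come from a functional assay on HEK293 cells (Homo sapiens) for cytotoxicity (a lower number here means that less compound is tolerated, a higher number that more compound is tolerated), and each one is a limit of the assay, not a number. Compound 3 stands only at a limit, > 10000 nM. The other two compounds share it, as the limit of > 10000 nM in this assay, at which 3 of the 3 values shown sit, shows.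

Compound 4 `COc1ccc([C@H]2CC(=O)N(c3cccc(S(C)(=O)=O)c3)C2)cc1OC1CCCC1` is the next to be measured. Its change from compound 3 is this: 3-(methylsulfonyl)phenyl in place of 4-(trifluoromethyl)phenyl on an amide-type nitrogen in a ring. In words, 3-(methylsulfonyl)phenyl takes the place of 4-(trifluoromethyl)phenyl on an amide-type nitrogen in a ring, while the rest of the structure stays the same.

Among the measured compounds shown here, three measured steps bear on this change, since each swaps the group on that same nitrogen: a step that the two limits leave unreadable from compound 1 to compound 2, a step that the two limits leave unreadable from compound 1 to compound 3 and a step that the two limits leave unreadable from compound 2 to compound 3. None of them has a readable size, so none supplies a number to carry over. For the measured compounds named here, still, all three groups left the result at the limit, and no measured compound goes against that. In this assay, no step beyond the scatter is therefore expected, in either direction. The expected step is a step that the limit leaves unreadable from compound 3 to compound 4. Most likely the assay will again report only a limit. For compound 4 the estimate is 15000 nM, within an expected range of 7000 nM to 40000 nM.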

Compound 4, half-maximal cytotoxic concentration: > 10000 nM
Compound 4: no number, only a limit; the forecaster's own chance of this, stated with the estimate: 90%; the middle value does not contradict the limit.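

Among the compounds shown here, compound 4, like compound 1, compound 2 and compound 3, gives only a limit in this assay, and no step from any of them to compound 4 can be read: the limit of > 10000 nM in this assay, at which 4 of the 4 values shown sit. The compounds shown leave open how much of each compound is tolerated beyond that limit, and whether the group on the amide-type nitrogen in a ring matters there.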